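Inverting One Stereocentre of the More Active Compound

This account rests on a few compounds, and the source may have more. Where it says the series, first, only, none or still open, it means among the compounds named here.

So far, two compounds have been measured in a functional assay on HCT-116 cells (Homo sapiens) for cytotoxicity, read by hypoxanthine incorporation, with a stated time of 72 h, tested at 10 uM; on this read-out lower numbers stand for less inhibition of growth and higher numbers for more inhibition of growth at the one concentration tested. Compound 1 `CC(C)[C@H]1NC(=O)[C@@H](Cc2ccccc2)N(C)C(=O)[C@H](Cc2ccccc2)NC(=O)[C@H](CO)NC(=O)[C@H](CC2CCCCC2)NC1=O` gives 18%, and compound 2 `CC(C)C[C@@H]1NC(=O)[C@@H]([C@H](OCc2ccccc2)c2ccccc2)NC(=O)[C@@H](Cc2ccccc2)NC(=O)[C@@H](CC(C)C)NC(=O)[C@H](C(C)C)N(C)C1=O` gives 94%. Compound 2 therefore holds the higher of the two numbers, and its gap to compound 1 lies beyond the usual scatter. These two compounds differ in several places, so their gap cannot be tied to any single change.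

Compound 3 `CC(C)C[C@@H]1NC(=O)[C@@H]([C@@H](OCc2ccccc2)c2ccccc2)NC(=O)[C@@H](Cc2ccccc2)NC(=O)[C@@H](CC(C)C)NC(=O)[C@H](C(C)C)N(C)C1=O` has not yet been measured. Set against compound 2, it shows (the two compounds have the same atoms and bonds and differ only in configuration as drawn: 1 of 6 stereo elements differ; a stereocentre at a saturated chain carbon is drawn R in compound 2 and S in compound 3), with a stereocentre at a saturated chain carbon drawn R in compound 2 and S in compound 3. Going by the values given here, no measured pair shows what such an inversion does in this assay, so the expectation remains broad. With compound 2 at 94%, little room remains for a rise, so a drop beyond the scatter is expected, though its size is uncertain. The estimated change is a number 22 percentage points lower from compound 2 to compound 3 (beyond the scatter). For compound 3 the estimated value is 72%, with an expected range of 35% to 98%.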

Compound 3, percent growth inhibition at one concentration: 63%
Compound 3: middle estimate off by 9 percentage points, on the high side; the range from low to high includes it.
By their numbers in this assay, from the lowest: compound 1; then compound 3; then compound 2.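

In this assay, inverting the stereocentre at this saturated chain carbon from R to S gives a number 31 percentage points lower from compound 2 to compound 3 (beyond the scatter). Going by these compounds alone, this is the first step that can be read as a single change, and it shows that the configuration at this one carbon matters on its own for growth inhibition at the concentration tested, with no atom added or removed. The size of the step can be assigned to this inversion alone, and not to any other feature of the structures, because nothing else separates the pair: the fact that compounds 2 and 3 differ only in the configuration as drawn

The compounds shown leave open whether inverting any of the other stereo elements has an effect of similar size, and what lies behind this one, since a single pair gives a direction at one position and no explanation for it. They also leave open whether the preference for the R drawing would hold if an amine or a carboxylic acid stood on this carbon in place of the present substituent, or whether the gap between the two configurations would then shrink, widen or reverse.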